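Amide aryl swap: fluoro-methoxy benzamide on the shared core

The source may hold more compounds than are shown below. What is called first, only, known or untested is meant among the compounds shown, and "the series" means these compounds.

Compound 2 `CCc1ccc(C(=O)Nc2cccc(-c3oc4cc(-c5ccc(F)cc5)ccc4c(=O)c3O)c2)cc1` gives the lower of the two numbers in a functional assay on MDA-MB-231 cells (Homo sapiens) for antiproliferative activity, read by CCK-8 assay, with a stated time of 72 h (a higher number here means a weaker inhibitor, a lower number a stronger inhibitor), with 9070 nM. Compound 1 `COc1ccc(C(=O)Nc2cccc(-c3oc4cc(-c5ccc(F)cc5)ccc4c(=O)c3O)c2)cc1` gives 16500 nM in this assay, and the step of a 1.8-fold lower number from compound 1 to compound 2 (0.26 log units; within the scatter) stays within the scatter, so the two compounds are not separated on these data. Compound 3 `COc1ccc(C(=O)Nc2cccc(-c3oc4cc(-c5ccc(F)cc5)ccc4c(=O)c3O)c2)c(F)c1` carries the change (2-fluoro-4-methoxyphenyl in place of 4-ethylphenyl on a carbonyl carbon). For the measured compounds named here, the only measured step bearing on this change is the one from compound 1 to compound 2, which concerns the same aromatic substituent on the benzamide and was within the scatter; compound 3 returns the methoxy group of compound 1 and adds a fluorine, for which no measured step exists. No movement beyond the scatter is therefore expected in this assay, and the expected step is a 1.5-fold higher number from compound 2 to compound 3 (0.19 log units; within the scatter). Compound 3 is estimated at 14000 nM, with a range from 6000 nM to 32000 nM.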

Compound 3, half-maximal inhibitory concentration: 17600 nM
For compound 3 the middle estimate is 1.3-fold (0.10 log units) below the measured one, and the stated range covers the measured number.
By their numbers in this assay, from the lowest: compounds 2, 1 and 3 (each within the scatter of the next).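

In this assay, fluoro in place of hydrogen on an aromatic carbon gives a 1.1-fold higher number from compound 1 to compound 3 (0.03 log units; within the scatter), which puts a number on the added fluorine alone and does not separate the two compounds. The exchange of 4-ethylphenyl for 2-fluoro-4-methoxyphenyl on a carbonyl carbon gives a 1.9-fold higher number from compound 2 to compound 3 (0.29 log units; within the scatter), so all three aryl groups on this amide lie within the scatter of one another on these data. Nothing available here speaks to a cause for these steps.

From the compounds shown here alone, whether an amine or a carboxylic acid on this aryl group, or a longer chain in place of the ethyl, would move the number beyond the scatter remains open. Also open, going by these compounds, is whether this flat reading holds in other cell lines.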